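Swapping the Side Group on a Shared Core

A few compounds are considered here, and "the series" means these few. Any claim that something is new, unique, unknown or untested is made for them only; others in the source may bear on it.

Measured compounds:
Compound 1, `CCN(CC)c1nc(C)nc2c1nnn2-c1ccc(C(C)C)cc1Br`: 25.3 nM
Compound 2, `CCC(Nc1nc(C)nc2c1nnn2-c1ccc(C(C)C)cc1Br)C(=O)OC`: 19.4 nM

Both compounds were tested in an in vitro assay on 293-EBNA cells for binding affinity to corticotropin-releasing factor receptor 1 (Homo sapiens); on this read-out lower numbers stand for stronger inhibition and higher numbers for weaker inhibition. Within the data shown here, compound 2 gives the lowest of the two numbers; its nearest neighbour is compound 1, and the one step between them, a 1.3-fold lower number from compound 1 to compound 2 (0.12 log units; within the scatter), lies within the scatter. So on the numbers shown, the two compounds cannot be told apart.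

Compound 3, `CCC(CC)Oc1nc(C)nc2c1nnn2-c1ccc(C(C)C)cc1Br`, has not yet been measured in this assay. It differs from compound 2 as follows: a group of 6 heavy atoms (5 carbon, 1 oxygen; no ring) in place of a group of 8 heavy atoms (5 carbon, 1 nitrogen, 2 oxygen; no ring), on an aromatic carbon. The group that enters is (pentan-3-yl)oxy, on the same aromatic carbon where compound 1 and compound 2 already differ from each other.

Among the measured compounds shown here, the only step that bears on this change is a 1.3-fold lower number from compound 1 to compound 2 (0.12 log units; within the scatter), and it stayed within the scatter; there is no measured change that swaps a nitrogen-linked group for an oxygen-linked one at this carbon. The expectation for compound 3 is therefore a small step, a 1.1-fold higher number from compound 2 to compound 3 (0.05 log units; within the scatter), most likely not beyond the scatter. The estimate for compound 3 in this assay is 22 nM, with a range from 8 nM to 65 nM.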

Compound 3, inhibition constant: 1.9 nM
The estimate for compound 3 lay 12-fold (1.06 log units) above the measured number; measured number outside the range, below it.
By their numbers in this assay, from the lowest: compound 3; then compounds 2 and 1 (each within the scatter of the next).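

In this assay the group on this aromatic carbon can shift the number well beyond the scatter, as (pentan-3-yl)oxy shows with a 10-fold lower number from compound 2 to compound 3 (1.01 log units; beyond the scatter) and with a 13-fold lower number from compound 1 to compound 3 (1.12 log units; beyond the scatter) on the same shared core. The earlier pair, compound 1 and compound 2, carried two different nitrogen-linked groups and could not be told apart, so they gave no sign that a change here could matter this much. Nothing measured here bears on the reason for the drop.

As far as these compounds go, each step replaces the linking atom and the rest of the group together, so it stays open whether the oxygen or the pentan-3-yl chain accounts for the drop, and the amine carrying that same pentan-3-yl chain would separate the two. The compounds shown also leave open how a smaller ether such as methoxy, or a ring-bearing one such as benzyloxy, would read.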